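This account rests on a few compounds, and the source may have more. Where it says the series, first, only, none or still open, it means among the compounds named here.

Working notes on the series. Of the compounds shown here, three of the shared core have been measured in an assay on isolated protein with Bile acid receptor (Homo sapiens) as the target; a higher number here means that more compound is needed for the effect, a lower number that less compound is needed. Compound 1 `CCOc1cccc(-c2ccc(CN(C(=O)C(C)C)c3cccc(/C=C/C(=O)OC)c3)cc2)c1` gives 173 nM. Compound 2 `COC(=O)/C=C/c1cccc(N(Cc2ccc(-c3ccc(C)cc3)cc2)C(=O)C(C)C)c1` gives 118 nM. Compound 3 `COC(=O)/C=C/c1cccc(N(Cc2ccc(-c3ccc(N(C)C)cc3)cc2)C(=O)C(C)C)c1` gives 57 nM, the lowest of the three numbers; the step of a 2.1-fold lower number from compound 2 to compound 3 (0.32 log units; beyond the scatter) and the step of a 3.0-fold lower number from compound 1 to compound 3 (0.48 log units; beyond the scatter) are both beyond the scatter, so compound 3 stands apart from the other two, while the step of a 1.5-fold lower number from compound 1 to compound 2 (0.17 log units; within the scatter) lies within the scatter.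

Compound 4 `COC(=O)/C=C/c1cccc(N(Cc2ccc(/C=C/c3ccccc3)cc2)C(=O)C(C)C)c1` is not yet measured. Its change from compound 3: 2-phenylethenyl in place of 4-(dimethylamino)phenyl on an aromatic carbon. Going by the values given here, the measured steps all swap one substituted phenyl for another at this same aromatic carbon; none of them exchanges the phenyl ring for a 2-phenylethenyl, so no step matches the change directly. Among the compounds with values here, the steps that bear on it show modest movement: the step of a 2.1-fold lower number from compound 2 to compound 3 (0.32 log units; beyond the scatter) and the step of a 3.0-fold lower number from compound 1 to compound 3 (0.48 log units; beyond the scatter), both modest. Compound 4 lacks the dimethylamino that set compound 3 apart, so a number nearer those of compound 1 and compound 2 is expected, estimated as a 2.1-fold higher number from compound 3 to compound 4 (0.32 log units; beyond the scatter). For compound 4 in this assay the expected value is 120 nM, with a range from 45 nM to 320 nM.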

Compound 4, half-maximal effective concentration: 65 nM
The estimate for compound 4 lay 1.8-fold (0.27 log units) above the measured number; the range from low to high includes it.
By their numbers in this assay, from the lowest: compounds 3, 4, 2 and 1 (each within the scatter of the next, the first and the last beyond it).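

In this assay, the step of a 1.1-fold higher number from compound 3 to compound 4 (0.06 log units; within the scatter) shows that the dimethylamino is not needed at this position for a number of this size: 2-phenylethenyl, with no nitrogen and no hydrogen-bond acceptor, stands level with 4-(dimethylamino)phenyl on the same aromatic carbon, para to a large group. The step of a 1.8-fold lower number from compound 2 to compound 4 (0.26 log units; within the scatter) is also within the scatter, so compound 4 cannot be separated from compound 2 either, even though the step of a 2.1-fold lower number from compound 2 to compound 3 (0.32 log units; beyond the scatter) lies beyond it, and the data therefore do not tie compound 3's place in the series to the dimethylamino alone. Going by these compounds alone, only the step of a 2.7-fold lower number from compound 1 to compound 4 (0.43 log units; beyond the scatter) lies beyond the scatter, which shows that a group with a double bond outside aromatic rings is accepted at this carbon and separates from 3-ethoxyphenyl. Nothing available gives a reason for these steps.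

Open, as far as these compounds go, is whether the double bond itself matters, which a saturated 2-phenylethyl in place of 2-phenylethenyl would test. Also open, from the compounds shown here alone, is whether a dimethylamino on the terminal phenyl of 2-phenylethenyl would move the number further from that of compound 4.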